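Switching the aryl ether of compound 3 for a thioether

A few compounds are considered here, and "the series" means these few. Any claim that something is new, unique, unknown or untested is made for them only; others in the source may bear on it.

Compound 3 `CC(C)(Oc1ccccc1O)C1OCC(C/C=C\CCC(=O)O)C(c2cccnc2)O1` gives 32 nM in an assay for inhibition of Thromboxane-A synthase (Homo sapiens), using microsomes (on this read-out higher numbers stand for weaker inhibition and lower numbers for stronger inhibition), the lowest of the three numbers measured, though within the scatter of both neighbours. Compound 1 `COc1ccc(OC(C)(C)C2OCC(C/C=C\CCC(=O)O)C(c3cccnc3)O2)cc1` gives 41 nM in this assay, and compound 2 `CC(C)(Oc1ccccc1F)C1OCC(C/C=C\CCC(=O)O)C(c2cccnc2)O1` gives 45 nM. The three steps that link them are all small: a 1.1-fold higher number from compound 1 to compound 2 (0.04 log units; within the scatter), a 1.3-fold lower number from compound 1 to compound 3 (0.11 log units; within the scatter) and a 1.4-fold lower number from compound 2 to compound 3 (0.15 log units; within the scatter). Across these three compounds the aryl group on the oxygen changes without any shift beyond the scatter.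

Compound 4 `Cc1ccc(SC(C)(C)C2OCC(C/C=C\CCC(=O)O)C(c3cccnc3)O2)c([N+](=O)[O-])c1` differs from compound 3 in that part of the structure: a group of 11 heavy atoms (7 carbon, 1 nitrogen, 2 oxygen, 1 sulfur; one six-membered aromatic ring of carbon only) in place of a group of 8 heavy atoms (6 carbon, 2 oxygen; one six-membered aromatic ring of carbon only), on a saturated chain carbon bound to two saturated chain carbons and a saturated ring carbon. The measured steps bear on this change only in part, since each of them swaps one aryl group for another on the same oxygen, and none of them replaces the oxygen itself with sulfur or introduces a nitro group; the steps that were measured were all within the scatter. For the measured compounds named here, with that as the only guide, the number for compound 4 in this assay is expected to stay close to that of compound 3, as a step of a 1.3-fold higher number from compound 3 to compound 4 (0.10 log units; within the scatter), with no direction beyond the scatter predicted. Compound 4 is therefore estimated at 40 nM in this assay, within a range from 15 nM to 110 nM.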

Compound 4, half-maximal inhibitory concentration: 30 nM
The estimate for compound 4 lay 1.3-fold (0.12 log units) above the measured number; the measured number falls inside the stated range.
By their numbers in this assay, from the lowest: compounds 4, 3, 1 and 2 (each within the scatter of the next).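

In this assay, replacing the 2-hydroxyphenoxy group with a larger group that carries sulfur and nitrogen gives a 1.1-fold lower number from compound 3 to compound 4 (0.03 log units; within the scatter) as the step, while the two other steps to the new compound read a 1.5-fold lower number from compound 2 to compound 4 (0.18 log units; within the scatter) and a 1.4-fold lower number from compound 1 to compound 4 (0.14 log units; within the scatter) and also stay within the scatter. The earlier compounds shown here only exchanged one aryl group for another on the same oxygen, whereas this result shows that, for this one compound, the place on the saturated chain carbon accepts a sulfur link, a group of 11 heavy atoms and the change to 0 hydrogen-bond donors with no shift beyond the scatter. No measurement accompanies these numbers that could account for this flat result.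

From the compounds shown here alone, the sulfur, the nitro group and the methyl group all enter in a single step, so the share of each in the result cannot be separated, and the oxygen-linked or sulfur-linked partner of each aryl group remains unknown. Going by these compounds, it is also open whether the number would stay in this range with an amine on the aromatic ring, or with a longer chain in place of the aromatic ring at this position.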